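The source may hold more compounds than are shown below. What is called first, only, known or untested is meant among the compounds shown, and "the series" means these compounds.

Of the compounds shown here, three built on a shared core have been measured in a functional assay on SNB-19 cells (Homo sapiens) for inhibition, read by sulforhodamine B assay, with a stated time of 48 h; on this read-out higher numbers stand for weaker inhibition of growth and lower numbers for stronger inhibition of growth. Compound 1, `COc1cc(-c2nn(-c3cccc(NC(=O)Nc4cc(C(F)(F)F)cc(C(F)(F)F)c4)c3)cc2-c2ccncc2)ccc1Cl`, gives 3670 nM. Compound 2, `COc1cc(-c2nn(-c3cccc(NC(=O)Nc4ccc(Cl)c(Cl)c4)c3)cc2-c2ccncc2)ccc1Cl`, gives only a limit of the assay, > 50000 nM, and not a number. Compound 3, `O=C(Nc1cccc(-n2cc(-c3ccncc3)c(-c3ccc(Cl)c(O)c3)n2)c1)Nc1ccc(Cl)c(Cl)c1`, likewise gives only a limit, > 32500 nM. Among the compounds with values here, the single change that can be followed between measured compounds, hydrogen in place of methyl on an oxygen on an aromatic ring, gives a step that the two limits leave unreadable from compound 2 to compound 3; its two ends sit at the limit of > 50000 nM in this assay, at which 1 of the 3 values shown sits, and (the limit of > 32500 nM in this assay, at which 1 of the 3 values shown sits), so its size cannot be read. Compound 2 thus stands among the values shown only as a limit, with no number to compare against. Within the data shown here, compound 1 gives a number where compound 2 gives only a limit, but no step between that pair is given.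

Compound 4, `COc1cc(-c2nn(-c3cccc(NC(=O)c4ccc(Cl)c(C(F)(F)F)c4)c3)cc2-c2ccncc2)ccc1Cl`, differs from compound 2 by 4-chloro-3-(trifluoromethyl)phenyl in place of (3,4-dichlorophenyl)amino on a carbonyl carbon. Among the measured compounds shown here, no measured step bears on this change, and the one measured step is unreadable, so the expectation rests on little. For compound 4 in this assay the estimated value is 20000 nM, expected to fall between 3000 nM and 50000 nM, which means an expected step of an at least 2.5-fold lower number from compound 2 to compound 4 (0.39 log units; beyond the scatter) whose direction is uncertain and which may again end at a limit.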

Compound 4, concentration for total growth inhibition: > 32500 nM
Compound 4 was reported as a limit; the forecaster's own chance of this, stated with the estimate: 50%; at least 1.6-fold (0.21 log units) between middle value and limit.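

Within the data shown here, compound 4 gives only a limit and not a number, as compound 2 does, so no step between compound 2 and compound 4 can be read. The compounds shown leave open whether 4-chloro-3-(trifluoromethyl)phenyl in place of (3,4-dichlorophenyl)amino changes growth inhibition at all.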